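A Fluoropyridinyl Swap Carried Over to a Second Core

The source may hold more compounds than are shown below. What is called first, only, known or untested is meant among the compounds shown, and "the series" means these compounds.

Compound 1 `O=C(NCCCCN1CCCCC1)Nc1ccc(-c2ccccc2)cc1` gives 7900 nM in a functional assay on HEK293 cells for agonist activity at 5-hydroxytryptamine receptor 3A (Homo sapiens), read by FLIPR; on this read-out lower numbers stand for stronger inhibition and higher numbers for weaker inhibition. Compound 2 `O=C(NCCCCN1CCCCC1)Nc1ccc(-c2ccc(F)nc2)cc1` differs from it by 6-fluoropyridin-3-yl in place of phenyl on an aromatic carbon. In this assay compound 2 reaches only the limit of > 30000 nM. That step is an at least 3.7-fold higher number from compound 1 to compound 2 (0.57 log units; beyond the scatter). Compound 3 `O=C(NCCCCN1CCCCC1)Nc1ccc(-c2ccccc2)nc1` has a different core, and the difference between the two cores is not broken down here. In this assay compound 3 likewise stands at the limit of > 30000 nM. Compound 4 `O=C(NCCCCN1CCCCC1)Nc1ccc(-c2ccc(F)nc2)nc1` carries the same kind of change on the core of compound 3: 6-fluoropyridin-3-yl in place of phenyl on an aromatic carbon. The surroundings differ, since on compound 1 the change sits on a six-membered aromatic ring of carbon only, whereas on compound 3 it sits on a six-membered aromatic ring with 1 nitrogen, next to the ring nitrogen.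

Because the limit of > 30000 nM in this assay, at which 2 of the 3 values shown sit, and because the earlier change weakened activity by an at least 3.7-fold higher number from compound 1 to compound 2 (0.57 log units; beyond the scatter), compound 4 is expected to remain at or beyond that limit. The estimated step from compound 3 is a step that the limit leaves unreadable from compound 3 to compound 4. Compound 4 is thus estimated at 60000 nM, within 20000 nM and 300000 nM.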

Compound 4, half-maximal inhibitory concentration in the 5-hydroxytryptamine receptor 3A assay: > 30000 nM
Compound 4 ended at the assay's limit; the forecaster's own chance of this, stated with the estimate: 85%; the middle value is on the limit's open side.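

In the 5-hydroxytryptamine receptor 3A assay compound 3 gives > 30000 nM, which is a limit of the assay. In the 5-hydroxytryptamine receptor 3A assay compound 4 gives > 30000 nM, which is also a limit of the assay. No step from compound 3 to compound 4 can be read in the 5-hydroxytryptamine receptor 3A assay, because both compounds sit at a limit of the assay: the limit of > 30000 nM in the 5-hydroxytryptamine receptor 3A assay, at which 3 of the 4 values shown sit.

In a physicochemical assay for solubility, at pH 7.4 (on this read-out higher numbers stand for higher solubility and lower numbers for lower solubility), compound 3 gives 193000 nM. In the physicochemical assay compound 4 gives 205000 nM. In the physicochemical assay the step is a 1.1-fold higher number from compound 3 to compound 4 (0.03 log units; within the scatter).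

The compounds shown leave open whether 6-fluoropyridin-3-yl in place of phenyl changes activity at all on the core of compound 3, and how much activity compound 3 and compound 4 actually have.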